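A few compounds are considered here, and "the series" means these few. Any claim that something is new, unique, unknown or untested is made for them only; others in the source may bear on it.

In a functional assay on HepG2 cells (Homo sapiens) for inhibition, read by MTT assay, with a stated time of 72 h (on this read-out lower numbers stand for stronger inhibition and higher numbers for weaker inhibition), compound 1 `O=C(Nc1cccc(OCc2cn(-c3ccccc3)nn2)c1)Nc1ccc(Cl)c(C(F)(F)F)c1` gives 1780 nM, compound 2 `CCc1ccccc1-n1cc(COc2cccc(NC(=O)Nc3ccc(Cl)c(C(F)(F)F)c3)c2)nn1` gives 3530 nM, and compound 3 `O=C(Nc1cccc(OCc2cn(-c3ccc(Br)cc3)nn2)c1)Nc1ccc(Cl)c(C(F)(F)F)c1` gives 2730 nM. The number for compound 3 is the second highest of the three, though all three lie within the scatter of one another. Compound 4 `O=C(Nc1cccc(OCc2cn(-c3ccccc3C(F)(F)F)nn2)c1)Nc1ccc(Cl)c(C(F)(F)F)c1` differs from compound 3 by 2-(trifluoromethyl)phenyl in place of 4-bromophenyl on an aromatic nitrogen. The measured steps that bear on this change all alter the aryl group on that aromatic nitrogen: a 2.0-fold higher number from compound 1 to compound 2 (0.30 log units; within the scatter), a 1.5-fold higher number from compound 1 to compound 3 (0.19 log units; within the scatter) and a 1.3-fold lower number from compound 2 to compound 3 (0.11 log units; within the scatter). None of them moved this assay beyond the scatter, so the expected step from compound 3 to compound 4 is a 1.1-fold lower number from compound 3 to compound 4 (0.02 log units; within the scatter), with no clear direction. For compound 4 the estimate in this assay is 2600 nM, expected to fall between 1200 nM and 5600 nM.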

Compound 4, half-maximal inhibitory concentration: 2320 nM
Compound 4: the middle estimate sits 1.1-fold (0.05 log units) above what was measured; the range from low to high includes it.
By their numbers in this assay, from the lowest: compounds 1, 4, 3 and 2 (each within the scatter of the next).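

In this assay the 2-(trifluoromethyl)phenyl group on the aromatic nitrogen gives a 1.2-fold lower number from compound 3 to compound 4 (0.07 log units; within the scatter) and a 1.5-fold lower number from compound 2 to compound 4 (0.18 log units; within the scatter) and a 1.3-fold higher number from compound 1 to compound 4 (0.12 log units; within the scatter) as its three steps. Trifluoromethyl thus joins ethyl and bromo as a third substituent on this phenyl group that leaves the number within the scatter of the unsubstituted compound 1, even with 10 heavy atoms entering in place of 7. No measurement here offers an explanation for this flat result. Still open, as far as these compounds go, is whether an amine or a carboxylic acid on this phenyl group would move the number beyond the scatter.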